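Methyl in Place of 4-Methylphenyl on the Ring Nitrogen

The source may report more compounds than this note shows. Statements on the series, on what has been measured and on what is new or still open speak of the compounds shown alone.

Among the measured compounds shown here, compound 2 `Cc1ccc(N2C(=O)NC3(CC3c3ccc4cccc(OCc5ccccc5)c4n3)C2=O)cc1` stands lowest of the two numbers so far: in a functional assay on the whole organism (strain Kunming) with Mus musculus as the target, in the maximal electroshock model, with a stated time of 0.5 h (on this read-out lower numbers stand for an effect already at smaller amounts and higher numbers for an effect only at larger amounts of compound), compound 2 gives 100 mg/kg, whereas compound 1 `O=C1NC(=O)C2(CC2c2ccc3cccc(OCc4ccccc4)c3n2)N1` gives 300 mg/kg. Compound 3 `CN1C(=O)NC2(CC2c2ccc3cccc(OCc4ccccc4)c3n2)C1=O` differs from compound 2 by methyl in place of 4-methylphenyl on an amide-type nitrogen in a ring. For the measured compounds named here, the only measured step that bears on it, a 3.0-fold lower number from compound 1 to compound 2 (0.48 log units; beyond the scatter), shows that a group on this nitrogen matters; a methyl is smaller than the 4-methylphenyl yet more than hydrogen, so a modest rise in number from compound 2 to compound 3 is expected, a 2.0-fold higher number from compound 2 to compound 3 (0.30 log units; within the scatter). Compound 3 is therefore estimated at 200 mg/kg, within 100 mg/kg to 400 mg/kg.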

Compound 3, minimum effective dose: 100 mg/kg
Estimate against measurement, compound 3: 2.0-fold (0.30 log units) above, within the range that was stated.
By their numbers in this assay, from the lowest: compounds 2 and 3 (each within the scatter of the next); then compound 1.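

In this assay the step with no change at the digits printed from compound 2 to compound 3 (within the scatter) shows that the 4-methylphenyl and its aromatic ring can give way to methyl on this amide-type nitrogen without a change beyond the scatter. The step with a 3.0-fold lower number from compound 1 to compound 3 (0.48 log units; beyond the scatter) shows that methyl in place of hydrogen is enough to give the same kind of gain that 4-methylphenyl gave. No evidence at hand explains this result.

On these data alone, what remains open is whether an ethyl group, a benzyl group or a longer chain ending in an amine on this nitrogen would lower the number further or raise it again.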